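Amide substituent: amino to carboxy on the shared core

A few compounds are considered here, and "the series" means these few. Any claim that something is new, unique, unknown or untested is made for them only; others in the source may bear on it.

Three compounds share one core and differ only at the amide-type nitrogen. Compound 1 `CCn1c(C(=O)NCCN)ccc1C(CC)(CC)c1ccc(OCS(=O)(=O)c2ccccc2)c(C)c1` gives 6430 nM in a functional assay on BXPC-3 cells (Homo sapiens) for antiproliferative activity, read by MTT assay, with a stated time of 24 h (on this read-out lower numbers stand for stronger inhibition and higher numbers for weaker inhibition), the lowest of the three numbers. Compound 2 `CCn1c(C(=O)N[C@@H](C)C(=O)O)ccc1C(CC)(CC)c1ccc(OCS(=O)(=O)c2ccccc2)c(C)c1` gives 20800 nM and compound 3 `CCn1c(C(=O)N[C@H](C(=O)O)C(C)C)ccc1C(CC)(CC)c1ccc(OCS(=O)(=O)c2ccccc2)c(C)c1` gives 16200 nM; the steps were a 3.2-fold higher number from compound 1 to compound 2 (0.51 log units; beyond the scatter) and a 2.5-fold higher number from compound 1 to compound 3 (0.40 log units; beyond the scatter), while a 1.3-fold lower number from compound 2 to compound 3 (0.11 log units; within the scatter). Compound 4 `CCn1c(C(=O)NCCC(=O)O)ccc1C(CC)(CC)c1ccc(OCS(=O)(=O)c2ccccc2)c(C)c1` is not yet measured; it differs from compound 1 by carboxy in place of amino on a saturated chain carbon, two bonds along the chain from an amide-type nitrogen. Both measured steps that removed an amino and brought a carboxy onto the chain at this nitrogen gave modestly higher numbers, so a step of similar size and the same direction is expected in this assay for compound 4. The expected step is a 2.5-fold higher number from compound 1 to compound 4 (0.40 log units; beyond the scatter). Compound 4 is estimated at 16000 nM, with a range from 8000 nM to 35000 nM.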

Compound 4, half-maximal inhibitory concentration: > 50000 nM
Compound 4 was reported as a limit; the forecaster's own chance of this, stated with the estimate: 5%; middle value at least 3.1-fold (0.49 log units) away from the limit.
By their numbers in this assay, from the lowest: compound 1; then compounds 3 and 2 (each within the scatter of the next). At a limit, above all of these: compound 4.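

In this assay compound 4 stands only as a limit, not a number: the limit of > 50000 nM in this assay, at which 1 of the 4 values shown sits. Replacing amino with carboxy on this chain costs more than the earlier changes suggested, with an at least 7.7-fold higher number from compound 1 to compound 4 (0.89 log units; beyond the scatter). The place of the carboxy on the chain also counts, since 2-carboxyethyl gives an at least 2.4-fold higher number from compound 2 to compound 4 (0.38 log units; beyond the scatter) and an at least 3.0-fold higher number from compound 3 to compound 4 (0.48 log units; beyond the scatter), so a carboxy on this amide-type nitrogen does not act the same wherever it sits.

Open, going by these compounds, is whether a longer chain ending in a carboxylic acid would behave like 2-carboxyethyl. Also open, on these data alone, is whether a methyl ester or primary amide in place of the carboxy would return towards compound 1.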